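This account rests on a few compounds, and the source may have more. Where it says the series, first, only, none or still open, it means among the compounds named here.

In a functional assay on A549 cells (Homo sapiens) for antiproliferative activity, read by MTT assay, with a stated time of 24 h (on this read-out lower numbers stand for stronger inhibition and higher numbers for weaker inhibition), compound 2 `O=c1[nH]cc(S(=O)(=O)Nc2ccccc2-c2cn(-c3ccc(F)cc3)nn2)c(=O)[nH]1` gives 6390 nM, the higher of the two numbers that have been measured. Going by the values given here, compound 1 `Cc1ccccc1-n1cc(-c2ccccc2NS(=O)(=O)c2c[nH]c(=O)[nH]c2=O)nn1` gives 3210 nM in this assay, and the only measured step, a 2.0-fold higher number from compound 1 to compound 2 (0.30 log units; within the scatter), lies within the scatter, so the two compounds cannot be told apart on these numbers.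

Compound 3 `O=c1[nH]cc(S(=O)(=O)Nc2ccccc2-c2cn(-c3cccc(Cl)c3)nn2)c(=O)[nH]1` has not yet been measured in this assay. It differs from compound 2 in one place: 3-chlorophenyl in place of 4-fluorophenyl on an aromatic nitrogen. Among the compounds with values here, the one measured step bears on this change only loosely, since it too swaps the group on the aromatic nitrogen of the shared core, and it did not move the number beyond the scatter. Within the data shown here, no step in the data involves a 3-chlorophenyl, so nothing supports an expectation of a step beyond the scatter in either direction for compound 3.

Compound 3 is therefore expected to land near compound 2, with an estimated step of a 1.3-fold lower number from compound 2 to compound 3 (0.11 log units; within the scatter), giving an estimated value of 5000 nM, with a range from 1500 nM to 16000 nM.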

Compound 3, half-maximal inhibitory concentration: 2340 nM
For compound 3 the middle estimate is 2.1-fold (0.33 log units) above the measured one; the range from low to high includes it.
By their numbers in this assay, from the lowest: compounds 3, 1 and 2 (each within the scatter of the next, the first and the last beyond it).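

In this assay, the group on the aromatic nitrogen now gives a step that clears the scatter, which the earlier step did not: a 2.7-fold lower number from compound 2 to compound 3 (0.44 log units; beyond the scatter), with 3-chlorophenyl in place of 4-fluorophenyl, so the number at this position does respond, if modestly, to the group it carries. Set against the 2-methylphenyl group, the same 3-chlorophenyl gives a 1.4-fold lower number from compound 1 to compound 3 (0.14 log units; within the scatter), so compound 1 and compound 3 cannot be told apart, and the only separation among the three compounds lies between compound 2 and compound 3. Nothing in the data shown accounts for this step.

All three compounds carry a substituted phenyl on this nitrogen, so they leave open whether the step follows the chlorine or its place on the ring, a question that a 4-chlorophenyl or a 3-fluorophenyl group would help to settle. They also leave open how the number would respond to an unsubstituted phenyl, a benzyl group or a saturated ring such as cyclohexyl at this position.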